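Trimethoxyphenyl in place of hydroxyphenyl on the shared core

The compounds below may be only part of what the source reports. "The series", "measured", "known", "first", "only" and "open" are said of these compounds alone.

Three pyrazoline sulfonamides built on the shared core of compound 1 `Cc1cc(O)c(C2=NN(c3ccc(S(N)(=O)=O)cc3)C(c3ccccc3O)C2)cc1Cl` have been measured in a functional assay on NCI-H322M cells (Homo sapiens) for antiproliferative activity, with a stated time of 48 h; on this read-out higher numbers stand for weaker inhibition of growth and lower numbers for stronger inhibition of growth. Compound 1 gives 7240 nM. Compound 2 `Cc1cc(O)c(C2=NN(c3ccc(S(N)(=O)=O)cc3)C(c3ccccc3Cl)C2)cc1Cl`, with chloro in place of hydroxy on an aromatic carbon, gives 5060 nM, a change of a 1.4-fold lower number from compound 1 to compound 2 (0.16 log units; within the scatter). Compound 3 `Cc1cc(O)c(C2=NN(c3ccc(S(N)(=O)=O)cc3)C(/C=C/c3ccccc3)C2)cc1Cl`, with 2-phenylethenyl in place of 2-hydroxyphenyl on a saturated ring carbon, gives 27500 nM, a change of a 3.8-fold higher number from compound 1 to compound 3 (0.58 log units; beyond the scatter); against compound 2 it shows a 5.4-fold higher number from compound 2 to compound 3 (0.74 log units; beyond the scatter). Compound 1 therefore stands second highest of the three numbers, close to compound 2 and well apart from compound 3.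

Compound 4 `COc1ccc(C2CC(c3cc(Cl)c(C)cc3O)=NN2c2ccc(S(N)(=O)=O)cc2)c(OC)c1OC` has not been measured. It differs from compound 1 by 2,3,4-trimethoxyphenyl in place of 2-hydroxyphenyl on a saturated ring carbon. The step from compound 1 to compound 2 shows that exchanging a hydroxy for another small group on that aryl ring leaves the number within the scatter, while the step from compound 1 to compound 3 shows that a different group on the saturated ring carbon can raise the number modestly. Going by the values given here, no measured step replaces the aryl ring by a trimethoxy-bearing one, so the estimate for compound 4 is expected to stay near compound 1, with a slight lean toward a higher number: a 1.2-fold higher number from compound 1 to compound 4 (0.09 log units; within the scatter), giving an expected 9000 nM within 3500 nM to 25000 nM.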

Compound 4, concentration for total growth inhibition: 12600 nM
Compound 4: middle estimate off by 1.4-fold (0.15 log units), on the low side, and the stated range covers the measured number.
By their numbers in this assay, from the lowest: compounds 2, 1 and 4 (each within the scatter of the next, the first and the last beyond it); then compound 3.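

In this assay, the exchange of 2-hydroxyphenyl for 2,3,4-trimethoxyphenyl on the saturated ring carbon brings 12 heavy atoms in place of 7 and 0 hydrogen-bond donors in place of 1, yet a 1.7-fold higher number from compound 1 to compound 4 (0.24 log units; within the scatter) keeps compound 4 within the scatter of compound 1. The same group is nevertheless set apart from the other two substituents at this position, with a 2.5-fold higher number from compound 2 to compound 4 (0.40 log units; beyond the scatter) against 2-chlorophenyl and a 2.2-fold lower number from compound 3 to compound 4 (0.34 log units; beyond the scatter) against 2-phenylethenyl. The aryl groups at this carbon therefore do not form a single level: compound 1 lies within the scatter of both compound 2 and compound 4, those two lie beyond it from each other, and all three give lower numbers than compound 3.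

Nothing available here bears on the cause of these differences. Still open, from the compounds shown here alone, is how this position would respond to an aryl ring carrying a single methoxy group, an amine or a carboxylic acid, or to a longer saturated chain in place of the aryl ring.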